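This account rests on a few compounds, and the source may have more. Where it says the series, first, only, none or still open, it means among the compounds named here.

Three analogues share a core and differ only in the substituted phenyl carried on the ether oxygen. Compound 3 `Cc1cc(OC[C@H](C)COc2ccc(C(=O)CC(C)(C)C)c(O)c2C)ccc1C(=O)O` gives 305 nM in an assay for positive allosteric modulation of metabotropic glutamate receptor 2 (Rattus norvegicus); a lower number here means that less compound is needed, a higher number that more compound is needed for the effect; compound 1 `Cc1c(OC[C@@H](C)COc2ccc(Cl)c(C(=O)O)c2)ccc(C(=O)CC(C)(C)C)c1O` gives 377 nM and compound 2 `Cc1c(OC[C@@H](C)COc2ccc(C(=O)O)cc2Cl)ccc(C(=O)CC(C)(C)C)c1O` gives 477 nM in this assay. The steps among them are small: a 1.3-fold higher number from compound 1 to compound 2 (0.10 log units; within the scatter), a 1.2-fold lower number from compound 1 to compound 3 (0.09 log units; within the scatter) and a 1.6-fold lower number from compound 2 to compound 3 (0.19 log units; within the scatter). Compound 3 has the lowest of the three numbers, but all three sit within the scatter of one another, so no order can be read from them.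

Compound 4 `COc1cc(OC[C@H](C)COc2ccc(C(=O)CC(C)(C)C)c(O)c2C)ccc1C(=O)O` differs from compound 3 in one place: methoxy in place of methyl on an aromatic carbon. Among the compounds with values here, no measured pair tests this exact exchange. The three recorded steps each swap the whole substitution pattern of the carboxy-bearing phenyl, a larger change than the present one, and each stayed within the scatter. They bear on the case only in showing that this part of the molecule tolerated rearrangement of small substituents without a shift beyond the scatter. On that basis the expected step is a 1.0-fold lower number from compound 3 to compound 4 (0.01 log units; within the scatter), none beyond the scatter. Compound 4 is therefore estimated at 300 nM in this assay, with a range from 150 nM to 600 nM.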

Compound 4, half-maximal effective concentration: 194 nM
Estimate against measurement, compound 4: 1.5-fold (0.19 log units) above; the range from low to high includes it.
By their numbers in this assay, from the lowest: compounds 4, 3, 1 and 2 (each within the scatter of the next, the first and the last beyond it).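

Methoxy in place of methyl on this aromatic carbon, ortho to a carboxy group and meta to a large group, gives a 1.6-fold lower number from compound 3 to compound 4 (0.20 log units; within the scatter) in this assay. This position therefore accepts one more heavy atom and one more hydrogen-bond acceptor with no shift beyond the scatter. The earlier steps shown here could not show this for a single position. Each of them exchanged the whole substitution pattern of the carboxy-bearing phenyl. No supporting data on the compounds bear on what lies behind this step, so the note rests on the measured numbers alone.

With only methyl and methoxy at this carbon, the extra heavy atom and the oxygen cannot be told apart, and a comparison with ethyl, ethoxy, hydroxyl, fluorine or an amine at the same place would be needed to separate them. Also open, from the compounds shown here alone, is how far the tolerance extends to a longer chain such as a propoxy or a benzyloxy group, and whether it holds when the carboxylic acid on the same ring is replaced by a primary amide or a tetrazole.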